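The source may hold more compounds than are shown below. What is called first, only, known or untested is meant among the compounds shown, and "the series" means these compounds.

Measured so far:
- compound 1, `COc1cc(NC(=O)Nc2cc(Nc3ccc(C)c(C)c3)ncn2)cc(OC)c1`: 45.3%
- compound 2, `COc1cc(NC(=O)Nc2cc(Nc3cccc(C(C)(C)C)c3)ncn2)cc(OC)c1`: 40%

In a functional assay on NCI-H226 cells (Homo sapiens) for inhibition, read by MTT assay, with a stated time of 48 h, tested at 10 uM (on this read-out higher numbers stand for more inhibition at the one concentration tested (going by the name of the read-out) and lower numbers for less inhibition), compound 2 gives the lower of the two numbers, with compound 1 nearest; the step of a number 5.3 percentage points lower from compound 1 to compound 2 (within the scatter) is within the scatter, so the two values cannot be ordered.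

The next compound is compound 3, `COc1cc(NC(=O)Nc2cc(Nc3ccc(F)c(Cl)c3)ncn2)cc(OC)c1`. It differs from compound 2 by 3-chloro-4-fluorophenyl in place of 3-(tert-butyl)phenyl on a nitrogen on an aromatic ring. Within the data shown here, the one measured step that bears on this change is the exchange of aryl groups on the same nitrogen from compound 1 to compound 2, and it was a number 5.3 percentage points lower from compound 1 to compound 2 (within the scatter), too small to tell apart from noise. Both aryl variants so far sit in the same band, and nothing in the series shows that a halogenated phenyl would move the number beyond the scatter. The expectation for compound 3 in this assay is therefore a step of about a number 2 percentage points higher from compound 2 to compound 3 (within the scatter), no change beyond the scatter in either direction.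

Estimated for compound 3: 42%, with a range from 25% to 60%.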

Compound 3, a percentage reported as inhibition, at one concentration (the size of the read-out at that concentration, not a potency): 36.7%
Compound 3: middle estimate off by 5.3 percentage points, on the high side; the measured number falls inside the stated range.
By their numbers in this assay, from the lowest: compounds 3, 2 and 1 (each within the scatter of the next).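

In this assay, placing 3-chloro-4-fluorophenyl on a nitrogen on an aromatic ring gives a step of a number 3.3 percentage points lower from compound 2 to compound 3 (within the scatter) against 3-(tert-butyl)phenyl and a step of a number 8.6 percentage points lower from compound 1 to compound 3 (within the scatter) against 3,4-dimethylphenyl, so the three aryl groups cannot be ordered. The two earlier compounds compared only alkyl-substituted phenyl groups; the series now shows that a phenyl group carrying chlorine and fluorine also gives no step beyond the scatter at this position. No supporting measurement bears on why these values lie so close together.

On these data alone, it remains open whether an aminophenyl group, a carboxylic acid on the phenyl ring, or a longer chain in place of the aryl group would give a step beyond the scatter. As far as these compounds go, the contribution of the rest of the shared core also remains open.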